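Ring substituent series: ethyl on the pyrazole nitrogen

This account rests on a few compounds, and the source may have more. Where it says the series, first, only, none or still open, it means among the compounds named here.

Compound 3 `c1ccc(-c2cn[nH]c2)c(NCC2=NCCN2)c1` sits second highest of the three numbers in an in vitro functional assay on cells (Fibroblast) for agonist activity at Alpha-1A adrenergic receptor (Homo sapiens) (on this read-out higher numbers stand for an effect only at larger amounts of compound and lower numbers for an effect already at smaller amounts), giving 1.26 nM; compound 1 `c1ccc(-c2nc[nH]n2)c(NCC2=NCCN2)c1` gives 0.794 nM and compound 2 `Cn1ccc(-c2ccccc2NCC2=NCCN2)n1` gives 3.16 nM. The step of a 1.6-fold higher number from compound 1 to compound 3 (0.20 log units; within the scatter) stays within the scatter, whereas a 4.0-fold higher number from compound 1 to compound 2 (0.60 log units; beyond the scatter) and a 2.5-fold lower number from compound 2 to compound 3 (0.40 log units; beyond the scatter) go beyond it. Compound 4 `CCn1cc(-c2ccccc2NCC2=NCCN2)cn1` differs from compound 3 by ethyl in place of hydrogen on an aromatic nitrogen. Going by the values given here, the only measured step touching an alkyl group on the ring nitrogen is a 2.5-fold lower number from compound 2 to compound 3 (0.40 log units; beyond the scatter), where the alkylated ring carries the higher number, though the attachment point also changes there. A modest rise is therefore expected for compound 4, about a 2.5-fold higher number from compound 3 to compound 4 (0.40 log units; beyond the scatter), so compound 4 is estimated at 3.2 nM with a range of 1.3 nM to 8 nM.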

Compound 4, half-maximal effective concentration: < 100000 nM
Compound 4 gave a limit, no number; the forecaster's own chance of this, stated with the estimate: 2%; the middle value is on the limit's open side.
By their numbers in this assay, from the lowest: compounds 1 and 3 (each within the scatter of the next); then compound 2.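

Compound 4 gives < 100000 nM, which is a limit and not a number. The step from compound 3 to compound 4 therefore cannot be read. The compounds shown leave open how ethyl in place of hydrogen on an aromatic nitrogen shifts the number in this assay.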